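The compounds below may be only part of what the source reports. "The series", "measured", "known", "first", "only" and "open" are said of these compounds alone.

Of the compounds shown here, three built on one shared core have been tested in an assay on membranes from HeLa cells for displacement of a labelled ligand from adenosine receptor A3 (Homo sapiens), read by scintillation counting, with a stated time of 180 min, tested at 1 uM; on this read-out higher numbers stand for more inhibition at the one concentration tested (going by the name of the read-out) and lower numbers for less inhibition. Compound 1 `CC1=C(C(=O)OCc2ccccc2)C(c2ccco2)NC(=O)N1` gives 3%, compound 2 `CC1=C(C(=O)C2CC2)C(c2ccco2)NC(=O)N1` gives 7%, and compound 3 `CC1=C(C(=O)SC(C)C)C(c2ccco2)NC(=O)N1` gives 1%. Compound 3 thus carries the lowest of the three numbers, yet its nearest neighbour is compound 1 and its furthest is compound 2, and both gaps lie within the scatter, so none of the three can be set apart from the others. For the measured compounds named here, the one single-point step among them, a number 6 percentage points lower from compound 2 to compound 3 (within the scatter), likewise stays within the scatter.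

Compound 4 `CC1=C(C(=O)OC2CCCCC2)C(c2ccco2)NC(=O)N1` has not yet been measured. It differs from compound 3 by cyclohexyloxy in place of isopropylsulfanyl on a carbonyl carbon. The step from compound 2 to compound 3 touches the same carbonyl carbon and was small, and compound 1, which also carries an ester at that carbonyl carbon, sits close to compound 3. Going by the values given here, nothing in the measured numbers suggests that exchanging groups at this carbonyl carbon moves the read-out beyond the scatter, so no step of note is expected. The expected step of a number 2 percentage points higher from compound 3 to compound 4 (within the scatter) is accordingly small. Compound 4 is estimated to give 3% in this assay, with a range from -5% to 12%.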

Compound 4, a percentage reported as inhibition, at one concentration (the size of the read-out at that concentration, not a potency): 4%
Compound 4: the middle estimate sits 1 percentage points below what was measured, and the stated range covers the measured number.
By their numbers in this assay, from the lowest: compounds 3, 1, 4 and 2 (each within the scatter of the next).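

In this assay, a cyclohexyloxy group, with its six-membered non-aromatic ring of carbon only, can stand on the carbonyl carbon in place of the open isopropylsulfanyl group without the number leaving the scatter (a number 3 percentage points higher from compound 3 to compound 4 (within the scatter)). The same holds when cyclohexyloxy replaces cyclopropyl (a number 3 percentage points lower from compound 2 to compound 4 (within the scatter)) and when cyclohexyl replaces benzyl on the oxygen next to the carbonyl group (a number 1 percentage points higher from compound 1 to compound 4 (within the scatter)), so a larger ring-bearing group and a swap of an aromatic for a non-aromatic ring on the ester oxygen both leave the four compounds inseparable at this one concentration. No evidence is available that bears on this result.

As far as these compounds go, whether an amine, a carboxylic acid or a longer chain on this carbonyl carbon would move the number beyond the scatter remains open. Also open, from the compounds shown here alone, is whether a change elsewhere on the shared core would do so, and the single-concentration numbers give no potency for any of the four compounds.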